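Swapping an Ester for an Amine on the Side Chain

The compounds below may be only part of what the source reports. "The series", "measured", "known", "first", "only" and "open" are said of these compounds alone.

Compound 1 `C[C@@H](Nc1c(C(=O)NCc2ccc(F)cc2)nc(Br)c2cccnc12)c1ccccc1`: in a functional assay on MDA-MB-435 cells (Homo sapiens) for cytotoxicity, read by MTT assay, with a stated time of 72 h (a higher number here means a weaker inhibitor, a lower number a stronger inhibitor), compound 1 gives > 20000 nM, which is a limit of the assay rather than a number.
Compound 2 `COC(=O)CNc1c(C(=O)NCc2ccc(F)cc2)nc(Br)c2cccnc12`: in this assay compound 2 gives 10000 nM.

For the measured compounds named here, compound 2 therefore holds the only numerical value in this set; the other entry is a limit (the limit of > 20000 nM in this assay, at which 1 of the 2 values shown sits). Going by the values given here, the single measured step runs an at least 2.0-fold lower number from compound 1 to compound 2 (0.30 log units; that floor lies within the scatter), and since one end of it is a limit, only its floor is known, and that floor lies within the usual scatter.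

Compound 3 `CNCCCNc1c(C(=O)NCc2ccc(F)cc2)nc(Br)c2cccnc12` differs from compound 2 in one place: 2-(methylamino)ethyl in place of methoxycarbonyl on a saturated chain carbon bound to a nitrogen on an aromatic ring. The measured step concerns the same side chain on the same nitrogen, but it exchanged a 1-phenylethyl for a (methoxycarbonyl)methyl, not an ester for an amine, so it bears on the new change only loosely. It shows that altering this chain can move the number at least to the floor of the scatter, but it gives no direction for the present swap. The expected step in this assay is therefore a 1.1-fold lower number from compound 2 to compound 3 (0.05 log units; within the scatter), which is not beyond the scatter. Compound 3 is estimated at 9000 nM, within a range from 2500 nM to 30000 nM.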

Compound 3, half-maximal inhibitory concentration: 11000 nM
Compound 3: middle estimate off by 1.2-fold (0.09 log units), on the low side; measured number inside the range.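

In this assay, putting 2-(methylamino)ethyl in place of methoxycarbonyl gives a 1.1-fold higher number from compound 2 to compound 3 (0.04 log units; within the scatter), so this exchange on a saturated chain carbon bound to a nitrogen on an aromatic ring does not separate the two compounds. The entering group brings a hydrogen-bond donor that the leaving group lacks and swaps the ester for an amine, yet the number does not move beyond the usual scatter, which the earlier step, starting from a limit, could not show for any pair of chains. Against the 1-phenylethyl chain the step is an at least 1.8-fold lower number from compound 1 to compound 3 (0.25 log units; that floor lies within the scatter) and only this floor is known, since one end of it is a limit of the assay: the limit of > 20000 nM in this assay, at which 1 of the 3 values shown sits.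

The compounds shown leave open whether any group on this chain can move the number clearly beyond the scatter, for instance a carboxylic acid in place of the ester, or a primary amine or a dimethylamine in place of the methylamine. They also leave open how a shorter or longer chain between the two nitrogens would read in this assay and whether a ring on the chain would matter.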